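Swapping the amine substituent from compound 2 to compound 3

A few compounds are considered here, and "the series" means these few. Any claim that something is new, unique, unknown or untested is made for them only; others in the source may bear on it.

Measured compounds:
compound 1, `C=C(C)c1ccc2ccn(CCN3CCCN(C)CC3)c2c1`, 72%
compound 2, `CC(C)CN1CCCN(CCn2ccc3ccc(Br)cc32)CC1`, 95%

Both compounds were tested in an assay on HEK293 cells for binding affinity to 5-hydroxytryptamine receptor 7 (Homo sapiens), read by radioligand binding, tested at 1 uM; a lower number here means less inhibition, a higher number more inhibition at the concentration tested (going by the name of the read-out). In this assay compound 1 gives 72%, and compound 2 gives 95%. Of the two numbers, compound 2 stands higher, and its gap to compound 1 lies beyond the usual scatter, so the inhibition in this assay is higher for compound 2 than for compound 1. Both compounds carry a seven-membered ring with two nitrogens attached through a two-carbon chain to the shared core; they differ at the core substituent and at the group on the ring amine nitrogen.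

Compound 3, `Brc1ccc2ccn(CCN3CCCN(C4CCCC4)CC3)c2c1`, has not yet been measured. Compared with compound 2 the change is cyclopentyl in place of isobutyl on an amine nitrogen in a ring. The bromine on the core is kept. Among the measured compounds shown here, no measured pair shows this particular change, so its effect can only be expected, not read off. Since compound 2 already gives 95%, little room remains above it, and the step of a number 3 percentage points lower from compound 2 to compound 3 (within the scatter) is expected to stay within the scatter. Compound 3 is therefore estimated to give 92%, within a range from 78% to 99%.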

Compound 3, a percentage reported as inhibition, at one concentration (the size of the read-out at that concentration, not a potency): 98%
For compound 3 the middle estimate is 6 percentage points below the measured one, within the range that was stated.
By their numbers in this assay, from the lowest: compound 1; then compounds 2 and 3 (each within the scatter of the next).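

Among the compounds shown here, putting cyclopentyl in place of isobutyl on the amine nitrogen in the ring gives a number 3 percentage points higher from compound 2 to compound 3 (within the scatter) in this assay and is the first change that can be read at a single place. This position therefore takes a five-membered non-aromatic carbon ring in place of an open isobutyl group with no change that can be told apart from the scatter. Both numbers lie close to the top of the percentage scale, though, and a reading at one concentration is not a potency, so a real difference between the two groups could stay hidden here.

On these data alone, it remains open whether a benzyl group or a chain ending in a carboxylic acid on the same nitrogen would hold inhibition at this level. Also open, as far as these compounds go, is how compound 2 and compound 3 would compare across a full range of concentrations, where the top of the scale would limit them less. Nothing available here explains why these two groups give such similar readings.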